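The source may hold more compounds than are shown below. What is called first, only, known or untested is meant among the compounds shown, and "the series" means these compounds.

Measured compounds:
compound 1 `CN(Cc1cc(C(F)(F)F)cc(C(F)(F)F)c1)C(=O)c1cnc2ccccc2c1-c1ccccc1` gives 0.03 nM in an in vitro assay on UC11MG cells for binding affinity to Substance-P receptor (Homo sapiens), read by radioligand binding; a higher number here means a weaker inhibitor, a lower number a stronger inhibitor;
compound 2 `COCc1nc2ccccc2c(-c2ccccc2)c1C(=O)N(C)Cc1cc(C(F)(F)F)cc(C(F)(F)F)c1` gives 11 nM in this assay;
compound 3 `NCc1nc2ccccc2c(-c2ccccc2)c1C(=O)NCc1cc(C(F)(F)F)cc(C(F)(F)F)c1` gives 0.0017 nM in this assay.

Among these three, compound 3 holds the lowest number, and both gaps to the others lie beyond the scatter, so it is the strongest inhibitor here. Compound 4 `O=C(NCc1cc(C(F)(F)F)cc(C(F)(F)F)c1)c1c(CN2C(=O)c3ccccc3C2=O)nc2ccccc2c1-c1ccccc1` is the next to be tested. Relative to compound 3 it carries a group of 11 heavy atoms (8 carbon, 1 nitrogen, 2 oxygen; one five-membered non-aromatic ring with 1 hetero atom, one six-membered aromatic ring of carbon only) in place of one nitrogen atom, on a saturated chain carbon bound to an aromatic carbon.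

Among the measured compounds shown here, only one measured step exists, a 370-fold higher number from compound 1 to compound 2 (2.56 log units; beyond the scatter), and it concerns a different change: a methoxymethyl group put on the shared core where compound 1 carries hydrogen. It is not the same move as replacing an amino group with a large two-ring group, so it does not directly speak to compound 4. Still, it is the one hint available, and it shows that adding bulk to this part of the core can cost a great deal. The change to compound 4 adds far more atoms than that step did and removes the hydrogen-bond donor of the amino group. A weakening is therefore expected, of a size comparable to that step or somewhat smaller, though the uncertainty is wide.

Compound 4 is expected to give 0.5 nM in this assay, within a range from 0.03 nM to 8 nM, which would mean an estimated step of a 290-fold higher number from compound 3 to compound 4 (2.47 log units; beyond the scatter).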

Compound 4, half-maximal inhibitory concentration: > 1000 nM
Compound 4 gave a limit, no number (the forecaster's own chance of this, stated with the estimate: 5%); middle value at least 2000-fold (3.30 log units) from the limit.
By their numbers in this assay, from the lowest: compound 3; then compound 1; then compound 2. At a limit, above all of these: compound 4.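

Compound 4 gives > 1000 nM in this assay and this is a limit of the assay, not a number. Going by these compounds, putting the group of 11 heavy atoms in place of the amino group, on a saturated chain carbon bound to an aromatic carbon, gives an at least 580000-fold higher number from compound 3 to compound 4 (5.76 log units; beyond the scatter) and so a very large loss of inhibition, whose full size stays unknown. Among the compounds shown here, the earlier compounds showed only that a methoxymethyl group in place of hydrogen on the shared core gives a 370-fold higher number from compound 1 to compound 2 (2.56 log units; beyond the scatter) and, on its own, compound 3 showed that an amino group on this chain can go with the lowest number of the set, whereas this pair shows that what the chain carbon holds can decide between that number and a value at the limit.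

The compounds shown cannot tell whether the loss follows from the size of the incoming group or from the departure of the amino group. A methylamine, a dimethylamine or an acetamide on the same chain carbon would fill the wide gap between these two extremes.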